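Stripping the acetylpiperazine from compound 3

A few compounds are considered here, and "the series" means these few. Any claim that something is new, unique, unknown or untested is made for them only; others in the source may bear on it.

- compound 1 `COc1cc(OC)c(Cl)c(-c2ccc3c(NC(=O)c4ccc(N5CCN(C6CCC6)CC5)cc4)n[nH]c3n2)c1Cl`: 2.3 nM
- compound 2 `C=CCN1CCN(c2ccc(C(=O)Nc3n[nH]c4nc(-c5c(Cl)c(OC)cc(OC)c5Cl)ccc34)cc2)CC1`: 3.3 nM
- compound 3 `COc1cc(OC)c(Cl)c(-c2ccc3c(NC(=O)c4ccc(N5CCN(C(C)=O)CC5)cc4)n[nH]c3n2)c1Cl`: 43.3 nM

In a functional assay on NCI-H1581 cells (Homo sapiens) for antiproliferative activity, read by CCK-8 assay, with a stated time of 72 h (on this read-out lower numbers stand for stronger inhibition and higher numbers for weaker inhibition), the highest number of the three belongs to compound 3 , with a 13-fold higher number from compound 2 to compound 3 (1.12 log units; beyond the scatter) and a 19-fold higher number from compound 1 to compound 3 (1.27 log units; beyond the scatter). The other two stay within the scatter of each other, with a 1.4-fold higher number from compound 1 to compound 2 (0.16 log units; within the scatter).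

The next structure is compound 4 `COc1cc(OC)c(Cl)c(-c2ccc3c(NC(=O)c4ccccc4)n[nH]c3n2)c1Cl`, which differs as follows: hydrogen in place of 4-acetylpiperazin-1-yl on an aromatic carbon. In words, hydrogen stands in place of 4-acetylpiperazin-1-yl on an aromatic carbon.

Within the data shown here, no measured step removes the whole ring, so the three steps bear on this change only indirectly. Both large steps show that a change at the far end of this group can move the number well beyond the scatter, and both end at compound 3. The data do not show what losing the entire group does. A moderate further rise is therefore expected, as a 2.8-fold higher number from compound 3 to compound 4 (0.44 log units; beyond the scatter), though with wide uncertainty. For compound 4 the estimated value is 120 nM, within an expected range of 25 nM to 600 nM.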

Compound 4, half-maximal inhibitory concentration: > 1000 nM
Compound 4 was reported as a limit; the forecaster's own chance of this, stated with the estimate: 5%; middle value at least 8.3-fold (0.92 log units) away from the limit.
By their numbers in this assay, from the lowest: compounds 1 and 2 (each within the scatter of the next); then compound 3. At a limit, above all of these: compound 4.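

Compound 4 stands in this assay as a limit, not as a number: the limit of > 1000 nM in this assay, at which 1 of the 4 values shown sits. Removing the whole 4-acetylpiperazin-1-yl group from this aromatic carbon gives an at least 23-fold higher number from compound 3 to compound 4 (1.36 log units; beyond the scatter), and the matching removals of the other two groups give an at least 300-fold higher number from compound 2 to compound 4 (2.48 log units; beyond the scatter) and an at least 430-fold higher number from compound 1 to compound 4 (2.63 log units; beyond the scatter). The earlier compounds shown here showed only that the far end of the group matters; these steps show that having any such group on this carbon matters too, even the acetyl form, and the size of the loss has only a lower bound.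

The compounds shown leave open whether the piperazine ring itself is needed, or whether a morpholine ring or a simple dimethylamino group on this carbon would recover the activity. They also leave open what a carboxylic acid at the far end of the piperazine would do.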